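The source may report more compounds than this note shows. Statements on the series, on what has been measured and on what is new or still open speak of the compounds shown alone.

In a functional assay on HeLa cells (Homo sapiens) for antiproliferative activity, read by MTT assay, with a stated time of 48 h (a higher number here means a weaker inhibitor, a lower number a stronger inhibitor), compound 2 `C=C(c1cc(OC)c(OC)c(OC)c1)c1ccc(OC)cc1NC(=O)CN` gives 70 nM and is the lower of the two numbers in hand. Compound 1 `C=C(c1ccc(OC)cc1NC(=O)CN)c1ccc(OC)c2c1C=CC(C)(C)O2` gives 200 nM in the same read-out, a gap beyond the scatter, but the two compounds differ in more than one place. For the measured compounds named here, no pair of measured compounds differs in one place only, so the series offers no direct precedent for the next change.

Compound 3 `C=C(c1cc(OC)c(OC)c(OC)c1)c1ccc(OC)cc1NC(=O)CN(C)C` departs from compound 2 by a single substitution: dimethylamino in place of amino on a saturated chain carbon bound to a carbonyl carbon with dimethylamino in place of amino on a saturated chain carbon bound to a carbonyl carbon. Without a precedent, only a small loss is expected, within the scatter. The expected move is a 1.7-fold higher number from compound 2 to compound 3 (0.23 log units; within the scatter) in the direction of a weaker inhibitor. In this assay compound 3 is estimated at 120 nM with 40 nM to 400 nM as the expected range.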

Compound 3, half-maximal inhibitory concentration: 370 nM
Estimate against measurement, compound 3: 3.1-fold (0.49 log units) below; low and high end bracket the measured number.
By their numbers in this assay, from the lowest: compound 2; then compounds 1 and 3 (each within the scatter of the next).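

For the compounds shown here, this is the first single-place step. In this assay, dimethylamino in place of amino on a saturated chain carbon bound to a carbonyl carbon gives a 5.3-fold higher number from compound 2 to compound 3 (0.72 log units; beyond the scatter), so this position does not tolerate the change without a loss beyond the scatter. The change takes the group from 1 hydrogen-bond donor to 0 and from 1 heavy atom to 3, and this single step cannot separate those two differences. No measurement in hand gives a reason for the loss.

Methylamino on the same carbon would help to separate the two differences, and how a longer chain or a carboxylic acid would fare at this place remains open. Also open, on these data alone, is whether the same change costs as much on the core of compound 1.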